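The source may hold more compounds than are shown below. What is called first, only, known or untested is meant among the compounds shown, and "the series" means these compounds.

Compound 1, `CCN1CCN(c2cc(C)c3cc(NC(=O)c4cccc(Cl)c4)ccc3n2)CC1`, was tested in a functional assay on SK-BR-3 cells (Homo sapiens) for antiproliferative activity, read by MTT assay, with a stated time of 72 h (a lower number here means a stronger inhibitor, a higher number a weaker inhibitor), where compound 1 gives 17800 nM. Among the compounds with values here, of the two compounds measured so far, compound 1 has the higher number. The other measured compound, compound 2, `CCN(CC)CCNc1cc(C)c2cc(NC(=O)c3ccc(Cl)c(Cl)c3)ccc2n1`, gives 3710 nM in this assay; since the two structures differ in more than one place, the pair shows only these two values and nothing about any single change.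

Compound 3, `CCc1ccccc1C(=O)Nc1ccc2nc(N3CCN(CC)CC3)cc(C)c2c1`, has not yet been measured. It differs from compound 1 in one place: 2-ethylphenyl in place of 3-chlorophenyl on a carbonyl carbon. Within the data shown here, no measured pair shows the effect of this change, so there is no direct basis for predicting a shift. The expected step is a 1.1-fold higher number from compound 1 to compound 3 (0.05 log units; within the scatter), which is within the usual scatter rather than a real change in either direction. On that basis compound 3 is expected to give about 20000 nM in this assay, with a likely range from 6000 nM to 60000 nM.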

Compound 3, half-maximal inhibitory concentration: 23900 nM
Beside the measured number, compound 3's estimate is 1.2-fold (0.08 log units) below it; low and high end bracket the measured number.
By their numbers in this assay, from the lowest: compound 2; then compounds 1 and 3 (each within the scatter of the next).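

In this assay, the step is a 1.3-fold higher number from compound 1 to compound 3 (0.13 log units; within the scatter), with 2-ethylphenyl in place of 3-chlorophenyl on the carbonyl carbon. This is the first change in a single place among these compounds, and it shows that these two groups cannot be told apart by this measurement, even though one carries chlorine and the other is all carbon with one more heavy atom. Nothing measured here offers an explanation for this result.

Going by these compounds, both groups are phenyl rings with no hydrogen-bond donors or acceptors, so it remains open whether an amine or a carboxylic acid on that ring would give a clearly different number. On these data alone, it is also open whether this result would hold with the rest of compound 2, which differs from compound 1 in more than one place.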